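The compounds below may be only part of what the source reports. "The series", "measured", "known", "first", "only" and "open" are said of these compounds alone.

Compound 1 `O=C1/C(=C/c2cccnc2)CN(S(=O)(=O)c2ccc(F)cc2)C/C1=C\c1ccccc1C(F)(F)F`: 2340 nM
Compound 2 `O=C1/C(=C/c2cccnc2)CN(S(=O)(=O)c2ccc(Cl)cc2)C/C1=C\c1ccccc1C(F)(F)F`: 3620 nM

Going by the values given here, in a functional assay on HepG2 cells (Homo sapiens) for cytotoxicity, read by MTT assay, with a stated time of 24 h (a lower number here means a stronger inhibitor, a higher number a weaker inhibitor), compound 2 gives 3620 nM, within the scatter of compound 1, the only other compound measured. Compound 3 `N#Cc1ccc(S(=O)(=O)N2C/C(=C\c3cccnc3)C(=O)/C(=C/c3ccccc3C(F)(F)F)C2)cc1` differs from compound 2 by cyano in place of chloro on an aromatic carbon, which puts cyano in place of chloro on an aromatic carbon. Among the compounds with values here, only one measured step bears on this: a 1.5-fold higher number from compound 1 to compound 2 (0.19 log units; within the scatter), with chloro in place of fluoro on an aromatic carbon. Within the data shown here, no cyano compound has been measured, so little guides the estimate, and no shift beyond the scatter is expected in this assay. The expected change is a 1.2-fold lower number from compound 2 to compound 3 (0.08 log units; within the scatter). Compound 3 is estimated at 3000 nM, with a range of 1200 nM to 7500 nM.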

Compound 3, half-maximal inhibitory concentration: 5060 nM
The estimate for compound 3 lay 1.7-fold (0.23 log units) below the measured number; low and high end bracket the measured number.
By their numbers in this assay, from the lowest: compounds 1, 2 and 3 (each within the scatter of the next, the first and the last beyond it).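

Going by these compounds alone, on the aromatic carbon para to a large group, cyano in place of chloro gives a 1.4-fold higher number from compound 2 to compound 3 (0.15 log units; within the scatter) in this assay and stays unresolved, whereas cyano in place of fluoro gives a 2.2-fold higher number from compound 1 to compound 3 (0.33 log units; beyond the scatter) as the first modest step at this position to pass the scatter. Replacing this substituent therefore moves the number only slightly across these three compounds. No available evidence accounts for this step.

As far as these compounds go, whether an amine, a carboxylic acid or a methoxy group here would move the number further remains open.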